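Swapping methyl for trifluoromethoxy on the pendant ring

The source may hold more compounds than are shown below. What is called first, only, known or untested is meant among the compounds shown, and "the series" means these compounds.

Measured so far:
compound 1 `Cc1cccc(-c2nc3cc(C)ccc3c(=O)[nH]2)c1`, 100%
compound 2 `Cc1ccc2c(=O)[nH]c(-c3ccccc3N(C)C)nc2c1`, 82.1%
compound 3 `Cc1ccc2nc(-c3cccc(F)c3)[nH]c(=O)c2c1`, 82.9%

Three compounds share one core and differ only in the group carried on the attached six-membered aromatic ring of carbon only. In an assay on isolated protein for inhibition of DNA topoisomerase 1 (Homo sapiens), with a stated time of 30 min, tested at 100 uM (on this read-out higher numbers stand for a stronger effect at the one concentration tested and lower numbers for a weaker effect), compound 1 gives 100%, the highest of the three numbers. Compound 3 gives 82.9% and compound 2 gives 82.1%; both of these stand below compound 1 by more than the usual scatter of repeated measurements, while the two of them lie within the scatter of each other.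

Compound 4 `Cc1ccc2c(=O)[nH]c(-c3cccc(OC(F)(F)F)c3)nc2c1` has not yet been measured in this assay. It differs from compound 1 in one place: trifluoromethoxy in place of methyl on an aromatic carbon. The group that enters is larger than the one that leaves, and it brings one hydrogen-bond acceptor where there was none. Since compound 1 already sits at the top of the range seen so far, a step up is not possible, and the step is expected to run downward, small and possibly within the scatter, at a number 15 percentage points lower from compound 1 to compound 4 (beyond the scatter). Compound 4 is therefore expected to show 85%, within a range from 65% to 100%.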

Compound 4, a percentage reported as inhibition, at one concentration (the size of the read-out at that concentration, not a potency): 77.2%
The estimate for compound 4 lay 7.8 percentage points above the measured number, within the range that was stated.
By their numbers in this assay, from the lowest: compounds 4, 2 and 3 (each within the scatter of the next); then compound 1.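

Among the compounds shown here, this is the first pair that differs in one place, so it gives the first direct reading of a change on this aromatic carbon, meta to a large group. In this assay, trifluoromethoxy in place of methyl gives a number 22.8 percentage points lower from compound 1 to compound 4 (beyond the scatter), which shows that the read-out responds to what this carbon carries, although compound 4 still reaches 77.2% at the one concentration tested. Nothing measured here explains the fall.

The step enlarges the group and adds a hydrogen-bond acceptor together, so the two changes cannot be told apart. On these data alone, how a nitrile, a carboxylic acid or an ethyl chain on the same carbon would read in this assay also remains open.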